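The source may report more compounds than this note shows. Statements on the series, on what has been measured and on what is new or still open speak of the compounds shown alone.

Compound 1 `COc1ccc(-c2cc3c(cn2)[nH]c(=O)n3-c2cc(OC)c(OC)c(OC)c2)cc1`: 840 nM
Compound 2 `COc1ccc(-c2cc3c(cn2)[nH]c(=O)n3-c2cc(OC)c(OC)c(OC)c2)cc1F`: 910 nM
Compound 3 `CCOc1ccc(-c2cc3c(cn2)[nH]c(=O)n3-c2cc(OC)c(OC)c(OC)c2)cc1`: 6660 nM

In a functional assay on HCT-116 cells (Homo sapiens) for antiproliferative activity, read by MTT assay, with a stated time of 48 h (on this read-out higher numbers stand for weaker inhibition and lower numbers for stronger inhibition), compound 1 has the lowest of the three numbers. Compound 2 sits close to it: a 1.1-fold higher number from compound 1 to compound 2 (0.03 log units; within the scatter). Compound 3 lies clearly higher: a 7.9-fold higher number from compound 1 to compound 3 (0.90 log units; beyond the scatter), and also a 7.3-fold higher number from compound 2 to compound 3 (0.86 log units; beyond the scatter).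

Compound 4 `COc1ccc(-c2cc3c(cn2)[nH]c(=O)n3-c2cc(OC)c(OC)c(OC)c2)cc1N` differs from compound 1 in one place: amino in place of hydrogen on an aromatic carbon. Among the compounds with values here, the step that bears most directly on this is the one from compound 1 to compound 2, which swaps a hydrogen for a fluoro on the same aromatic carbon and stays within the scatter. The step to compound 3 changes a different place, the methoxy group itself, and is the only one beyond the scatter. An amino group is a larger departure than a fluoro, bringing a hydrogen-bond donor and acceptor, so a somewhat weaker result than for compound 2 is plausible, but the available steps give no reason to expect a change as large as that to compound 3. For compound 4 the expected step is therefore a 1.5-fold higher number from compound 1 to compound 4 (0.19 log units; within the scatter), a small rise. Compound 4 is estimated at 1300 nM, within a range of 450 nM to 4000 nM.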

Compound 4, half-maximal inhibitory concentration: 820 nM
Compound 4: middle estimate off by 1.6-fold (0.20 log units), on the high side; the measured number falls inside the stated range.
By their numbers in this assay, from the lowest: compounds 4, 1 and 2 (each within the scatter of the next); then compound 3.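

In this assay, an amino group on this aromatic carbon, ortho to a methoxy group, gives a number within the scatter of the hydrogen compound (a 1.0-fold lower number from compound 1 to compound 4 (0.01 log units; within the scatter)) and of the fluoro compound (a 1.1-fold lower number from compound 2 to compound 4 (0.05 log units; within the scatter)). Hydrogen, fluoro and amino therefore cannot be told apart at this place, even though amino brings a hydrogen-bond donor that neither of the others has. The gap to the ethoxy compound stays beyond the scatter when 3-amino-4-methoxyphenyl replaces 4-ethoxyphenyl (an 8.1-fold lower number from compound 3 to compound 4 (0.91 log units; beyond the scatter)), and no measurement here explains any of these results.

From the compounds shown here alone, it remains open whether a much larger group at this carbon, such as a dimethylamino group or a carboxylic acid, would also leave the number within the scatter. Going by these compounds, it is also open whether an amino group here would give the same result with the ethoxy group in place of the methoxy group.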